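Changing the Aryl Group on the Double Bond

The source may hold more compounds than are shown below. What is called first, only, known or untested is meant among the compounds shown, and "the series" means these compounds.

Three compounds that share one core have been measured in a functional assay on DU-145 cells (Homo sapiens) for inhibition, read by trypan blue exclusion, with a stated time of 96 h; a higher number here means a weaker inhibitor of growth, a lower number a stronger inhibitor of growth:
compound 1 `Cc1ccc(C)c(/C=C(\C(=O)c2ccc(Cl)cc2)S(=O)(=O)Cc2ccc(Cl)cc2)c1` gives 10000 nM;
compound 2 `Cc1ccc(CS(=O)(=O)/C(=C/c2cc(C)ccc2C)C(=O)c2ccc(Cl)cc2)cc1` gives 1000 nM;
compound 3 `Cc1ccc(S(=O)(=O)/C(=C/c2cc(C)ccc2C)C(=O)c2ccc(Cl)cc2)cc1` gives 1000 nM.

Compound 2 stands level with compound 3 at the digits shown, and the two together hold the lowest numbers of the three. Compound 1 is the outlier: a 10-fold lower number from compound 1 to compound 2 (1.00 log units; beyond the scatter) and a 10-fold lower number from compound 1 to compound 3 (1.00 log units; beyond the scatter) both mark clear steps, while no change at the digits printed from compound 2 to compound 3 (within the scatter) lies within the scatter. Every one of these steps concerns the group on the sulfonyl sulfur or its ring substituent.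

Compound 4 `Cc1ccc(CS(=O)(=O)/C(=C/c2ccccc2Br)C(=O)c2ccc(Cl)cc2)cc1` differs from compound 2 in one place only: 2-bromophenyl in place of 2,5-dimethylphenyl on a double-bonded chain carbon bound to a double-bonded chain carbon. Among the compounds with values here, no measured step touches this part of the molecule, so none bears directly on the change. Without a guiding step, the expectation is that the number stays where compound 2 stands, with wide uncertainty on either side. For compound 4 the expected step is no change at the digits printed from compound 2 to compound 4 (within the scatter), that is, none beyond the scatter. Compound 4 is therefore estimated at 1000 nM, with a range from 250 nM to 4000 nM.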

Compound 4, concentration for 50% growth inhibition: 25000 nM
For compound 4 the middle estimate is 25-fold (1.40 log units) below the measured one; measured number above the stated range.
By their numbers in this assay, from the lowest: compounds 2 and 3 (each within the scatter of the next); then compound 1; then compound 4.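

In this assay, within the data shown here, the aryl group on the double bond proves to be a sensitive part of the molecule: a 25-fold higher number from compound 2 to compound 4 (1.40 log units; beyond the scatter) is a large step, whereas the earlier steps, all on the sulfonyl side, were modest or within the scatter. The two groups exchanged here are alike in what can be counted for them, each having one six-membered aromatic ring of carbon only, no hydrogen-bond donors or acceptors and no net charge, so this much weaker growth inhibition comes with a change in the ring's substituents alone, as the methyl groups leave and a bromine enters. No measurement at hand explains the size of this step.

The compounds shown cannot separate the effect of losing the methyl groups from that of gaining the bromine, and a plain phenyl, a 2-methylphenyl or a 2-chlorophenyl group at this place would help to tell these apart. From the compounds shown here alone, it also remains open whether the same exchange would have a similar effect with the 4-methylphenyl group of compound 3 on the sulfonyl sulfur.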